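Swapping the Five-Membered Ring for Pyrazine

A few compounds are considered here, and "the series" means these few. Any claim that something is new, unique, unknown or untested is made for them only; others in the source may bear on it.

Compound 2 `Cc1cnc(/C(=N\O)c2nc3ccccc3s2)s1` gives 29000 nM in an ADME assay on CHO cells (Cricetulus griseus) for cytotoxicity (a lower number here means a stronger inhibitor, a higher number a weaker inhibitor), the lowest of the two numbers shown, though the single recorded step, a 1.3-fold lower number from compound 1 to compound 2 (0.12 log units; within the scatter), leaves compound 1 `Cc1nnc(/C(=N\O)c2nc3ccccc3s2)s1` at 38000 nM within the scatter of it. Compound 3 `O/N=C(\c1cnccn1)c1nc2ccccc2s1` differs from compound 2 by pyrazin-2-yl in place of 5-methyl-1,3-thiazol-2-yl on a carbon with a double bond to nitrogen. Among the measured compounds shown here, the only step that bears on this is that earlier ring exchange, which stayed within the scatter, so no step beyond the scatter is expected in this assay. Compound 3 is therefore estimated at 30000 nM, between 12000 nM and 75000 nM. The expected step is a 1.0-fold higher number from compound 2 to compound 3 (0.01 log units; within the scatter).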

Compound 3, half-maximal inhibitory concentration: 11700 nM
The estimate for compound 3 lay 2.6-fold (0.41 log units) above the measured number, and the stated range ends above it.
By their numbers in this assay, from the lowest: compound 3; then compounds 2 and 1 (each within the scatter of the next).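

In this assay, the group on the carbon with a double bond to nitrogen can shift the number beyond the scatter: pyrazin-2-yl gives a 2.5-fold lower number from compound 2 to compound 3 (0.39 log units; beyond the scatter), and a 3.2-fold lower number from compound 1 to compound 3 (0.51 log units; beyond the scatter), both modest steps. The two five-membered aromatic rings had stayed within the scatter of each other, so only the six-membered aromatic ring separates here. Nothing on hand explains this shift.

From the compounds shown here alone, whether phenyl or pyridin-2-yl at this carbon would match compound 3 remains open. So does the effect of an amine on the pyrazin-2-yl ring.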